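Compound 3 and a solubility series read only at limits

The compounds below may be only part of what the source reports. "The series", "measured", "known", "first", "only" and "open" are said of these compounds alone.

In a physicochemical assay for solubility, in phosphate buffer, measured as kinetic solubility, at pH 7.4 (a lower number here means a less soluble compound, a higher number a more soluble compound), compound 1 `Cc1oc(-c2c(Cl)cccc2Br)nc1CN1CCC(C(=O)NCCCN2C[C@H](C)C[C@H](C)C2)CC1` gives > 83 ug/mL, which is a limit. Compound 2 `COc1cccc(F)c1-c1nc(CN2CCC(C(=O)NCCCN3C[C@H](C)C[C@H](C)C3)CC2)c(C)o1` gives > 74 ug/mL, which is also a limit, so compound 2 has no exact number. Compound 3 `Cc1cccc(C)c1-c1nc(CN2CCC(C(=O)NCCCN3C[C@H](C)C[C@H](C)C3)CC2)c(C)o1` replaces 2-fluoro-6-methoxyphenyl with 2,6-dimethylphenyl on the same aromatic carbon: 2,6-dimethylphenyl in place of 2-fluoro-6-methoxyphenyl on an aromatic carbon. Among the measured compounds shown here, the only measured step that bears on this change is a step that the two limits leave unreadable from compound 1 to compound 2, and it gives no usable size. No shift beyond the scatter is therefore expected in this assay, in either direction. The expected step is an at least 1.0-fold lower number from compound 2 to compound 3 (0.01 log units; that floor lies within the scatter). For compound 3, the estimate is 71 ug/mL, with an expected range of 40 ug/mL to 95 ug/mL.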

Compound 3, solubility: 55.9 ug/mL
For compound 3 the middle estimate is 1.3-fold (0.10 log units) above the measured one, and the stated range covers the measured number.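

Compound 3 gives the series its first exact number in this assay, so changes at this aromatic carbon can now be given a minimum size. Replacing 2-fluoro-6-methoxyphenyl with 2,6-dimethylphenyl gives an at least 1.3-fold lower number from compound 2 to compound 3 (0.12 log units; that floor lies within the scatter), and replacing 2-bromo-6-chlorophenyl with the same group gives an at least 1.4-fold lower number from compound 1 to compound 3 (0.17 log units; that floor lies within the scatter). Both are only floors, neither shows a shift beyond the scatter, and the step between compound 1 and compound 2 still cannot be read.

Going by these compounds, how far compound 1 and compound 2 truly lie from compound 3 remains open. Also open, on these data alone, is whether an amine or a carboxylic acid on the six-membered aromatic ring would move the number beyond the scatter.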